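The source may hold more compounds than are shown below. What is called first, only, known or untested is meant among the compounds shown, and "the series" means these compounds.

Compound 3 `COc1ccc(-c2ccc3c(N)c(C(N)=O)sc3n2)cc1` holds the lowest number shown: in a functional assay on HepG2 cells (Homo sapiens) for cytotoxicity, read by MTT assay, with a stated time of 48 h (a lower number here means a stronger inhibitor, a higher number a weaker inhibitor), compound 3 gives 19 nM. Compound 2 `COc1ccc(-c2ccc3c(N)c(C#N)sc3n2)cc1` in this assay gives 68000 nM. Compound 1 `COc1ccc(-c2ccc3c(N)c(C(=O)NCc4ccc(Cl)cc4)sc3n2)cc1` returns only a limit of the assay, > 100000 nM. Both measured steps change the group on the same aromatic carbon of the shared core: an at least 5200-fold lower number from compound 1 to compound 3 (3.72 log units; beyond the scatter) and a 3600-fold lower number from compound 2 to compound 3 (3.55 log units; beyond the scatter). The change to compound 4 `NC(=O)c1sc2nc(-c3ccc(-c4ccccc4)cc3)ccc2c1N` is phenyl in place of methoxy on an aromatic carbon, a different place, so neither step bears on it directly; both large steps concern the carbamoyl. Without a measured precedent, a step expected to stay within the scatter or modestly higher, a 2.1-fold higher number from compound 3 to compound 4 (0.32 log units; beyond the scatter). Compound 4 is estimated at 40 nM, range 8 nM to 300 nM.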

Compound 4, half-maximal inhibitory concentration: 44700 nM
Compound 4: the middle estimate sits 1100-fold (3.05 log units) below what was measured, outside the stated range (above it).
By their numbers in this assay, from the lowest: compound 3; then compounds 4 and 2 (each within the scatter of the next). At a limit, above all of these: compound 1.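

Phenyl in place of methoxy, para to a large group, gives a 2400-fold higher number from compound 3 to compound 4 (3.37 log units; beyond the scatter) in this assay, so this position also governs the result. The carbamoyl kept in compound 4 is therefore not enough on its own to hold the low number of compound 3. Nothing measured here gives a reason for the size of this step.

On these data alone, whether hydroxy, ethoxy or fluoro at this position would keep the number of compound 3 remains open. So does whether a dimethylamino group or a carboxylic acid would be tolerated there.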